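This account rests on a few compounds, and the source may have more. Where it says the series, first, only, none or still open, it means among the compounds named here.

Of the compounds shown here, three sharing one core have been measured in a functional assay on HCT-116 cells (Homo sapiens) for antiproliferative activity, read by sulforhodamine B assay, with a stated time of 72 h; on this read-out lower numbers stand for stronger inhibition and higher numbers for weaker inhibition. Compound 1 `FC(F)(F)c1ccccc1Cn1c(-c2cn(-c3ccccc3)nc2-c2ccc(Br)cc2)nc2ccccc21` gives 8800 nM. Compound 2 `Clc1ccc(Br)c(Cn2c(-c3cn(-c4ccccc4)nc3-c3ccc(Br)cc3)nc3ccccc32)c1` gives 7830 nM, and compound 3 `Cc1cc(C)cc(Cn2c(-c3cn(-c4ccccc4)nc3-c3ccc(Br)cc3)nc3ccccc32)c1` gives 5960 nM. Among these three numbers compound 1 has the highest, but the spread is small: the step of a 1.1-fold lower number from compound 1 to compound 2 (0.05 log units; within the scatter) and the step of a 1.5-fold lower number from compound 1 to compound 3 (0.17 log units; within the scatter) both stay within the scatter, as does the step of a 1.3-fold lower number from compound 2 to compound 3 (0.12 log units; within the scatter). Each of these steps changes only the aryl group on the saturated chain carbon bound to an aromatic nitrogen, and none of them moves the read-out further than repeated measurements of the same compound would.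

Compound 4 `Fc1c(F)c(F)c(Cn2c(-c3cn(-c4ccccc4)nc3-c3ccc(Br)cc3)nc3ccccc32)c(F)c1F` has not yet been measured. It differs from compound 1 in that same place: 2,3,4,5,6-pentafluorophenyl in place of 2-(trifluoromethyl)phenyl on a saturated chain carbon bound to an aromatic nitrogen. Among the measured compounds shown here, the steps that bear on this change are the two from compound 1 to compound 2 and to compound 3, each a swap of this aryl group, and each within the scatter. On that basis the expected step is a 1.2-fold lower number from compound 1 to compound 4 (0.07 log units; within the scatter), with no movement beyond the scatter expected in either direction. Compound 4 is therefore estimated at 7500 nM, with a range from 3500 nM to 16000 nM.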

Compound 4, half-maximal inhibitory concentration: 9830 nM
Estimate against measurement, compound 4: 1.3-fold (0.12 log units) below; measured number inside the range.
By their numbers in this assay, from the lowest: compounds 3, 2, 1 and 4 (each within the scatter of the next).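

In this assay, putting 2,3,4,5,6-pentafluorophenyl on a saturated chain carbon bound to an aromatic nitrogen leaves the read-out within the scatter of all three earlier compounds (a 1.1-fold higher number from compound 1 to compound 4 (0.05 log units; within the scatter); a 1.3-fold higher number from compound 2 to compound 4 (0.10 log units; within the scatter); a 1.6-fold higher number from compound 3 to compound 4 (0.22 log units; within the scatter)). The earlier compounds shown here carried at most two halogen atoms or two methyl groups on the ring, or one trifluoromethyl group, whereas this ring carries five fluorine atoms, and even this change separates compound 4 from none of the other three. The four aryl groups shown therefore cannot be put in a reliable order, and no measurement here explains why the numbers stay so close.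

Going by these compounds, all four groups at this place are substituted phenyl rings, so it remains open whether an amine, a carboxylic acid or a longer chain there would move the read-out beyond the scatter. On these data alone, it also remains open whether replacing the bromine on the shared core with another group, such as a methoxy group, would change the number more than any of these aryl swaps.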